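The source may hold more compounds than are shown below. What is called first, only, known or untested is meant among the compounds shown, and "the series" means these compounds.

Measured so far:
- compound 1, `Oc1ccc(-c2nc3cc(F)ccc3s2)cc1O`: 190 nM
- compound 2, `COc1cc(-c2nc3cc(F)ccc3s2)ccc1O`: 170 nM
- compound 3, `COc1cc(-c2nc3cc(F)ccc3s2)cc(OC)c1OC`: 2.1 nM

All three were tested in a functional assay on MDA-MB-468 cells (Homo sapiens) for antiproliferative activity; on this read-out higher numbers stand for weaker inhibition of growth and lower numbers for stronger inhibition of growth. Compound 3 gives the lowest number of the three, and its gaps to compound 2 and to compound 1 are both beyond the scatter of this assay. How the core of compound 3 differs from the core of compound 2 is not broken down here; the two differ in more than one place.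

Compound 4, `COc1cc(-c2nc3cc(F)ccc3s2)cc(O)c1OC`, has not yet been measured. It differs from compound 3 by hydrogen in place of methyl on an oxygen on an aromatic ring. The same change, at the same kind of place, has already been made once: compound 1 differs from compound 2 by hydrogen in place of methyl on an oxygen on an aromatic ring, and in this assay that step was a 1.1-fold higher number from compound 2 to compound 1 (0.05 log units; within the scatter). Since that earlier step lay within the scatter, the expectation for compound 4 is that the step from compound 3 will also be small, a 1.2-fold higher number from compound 3 to compound 4 (0.08 log units; within the scatter), resting on the near-equal numbers of compound 2 and compound 1. Compound 4 is therefore estimated at 2.5 nM, most likely between 1 nM and 7 nM.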

Compound 4, concentration for 50% growth inhibition: 88 nM
The estimate for compound 4 lay 35-fold (1.55 log units) below the measured number; measured number above the stated range.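

Replacing methoxy with hydroxy on the core of compound 3 gave a 42-fold higher number from compound 3 to compound 4 (1.62 log units; beyond the scatter) in this assay, so the near-silent result of this change on the other core did not carry over, as the two steps set side by side show: the same change on two cores in this assay, a 1.1-fold higher number (0.05 log units; within the scatter) from compound 2 to compound 1 and a 42-fold higher number (1.62 log units; beyond the scatter) from compound 3 to compound 4, 37-fold (1.57 log units) apart, beyond the scatter of two such steps The size of this step therefore depends on the core that carries it, and a step read on one of these cores is a poor guide to the same step on the other. This does not show why the two steps differ, and two pairs give no rule for the whole series; the two cores differ in more than one place, and these data cannot say which of those differences matters.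

The compounds shown leave open whether another group in that place on the core of compound 3, such as an amine or a longer chain like ethoxy, would keep its low number or lose it as hydroxy does. Also open, on these data alone, is how the same change behaves on a third core.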